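A few compounds are considered here, and "the series" means these few. Any claim that something is new, unique, unknown or untested is made for them only; others in the source may bear on it.

Measured so far in a functional assay on the whole organism (B cells) with Mus musculus as the target; a lower number here means a smaller maximal response, a higher number a larger maximal response:
compound 1 `CCOC(=O)Cn1c(=O)n(C2OC(CO)[C@@H](O)[C@H]2O)c2nc(N)nc(O)c21` gives 86%
compound 2 `Nc1nc(O)c2c(n1)n(C1OC(CO)[C@@H](O)[C@H]1O)c(=O)n2Cc1ccc(Cl)cc1` gives 15%
compound 3 `Nc1nc(O)c2c(n1)n(C1OC(CO)[C@@H](O)[C@H]1O)c(=O)n2Cc1ccc(OCc2ccccc2)cc1` gives 5%

Compound 2 stands second highest of the three numbers in this assay. Its nearest neighbour is compound 3, a number 10 percentage points lower from compound 2 to compound 3 (within the scatter), a gap within the scatter; its furthest is compound 1, a number 71 percentage points lower from compound 1 to compound 2 (beyond the scatter), well beyond it.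

Compound 4 `NC(=O)Cn1c(=O)n(C2OC(CO)[C@@H](O)[C@H]2O)c2nc(N)nc(O)c21` has not yet been measured. It differs from compound 2 in one place: carbamoyl in place of 4-chlorophenyl on a saturated chain carbon bound to an aromatic nitrogen.

Among the measured compounds shown here, only one measured step touches the same saturated chain carbon bound to an aromatic nitrogen: a number 71 percentage points lower from compound 1 to compound 2 (beyond the scatter), where ethoxycarbonyl gave way to 4-chlorophenyl and the maximal response fell sharply. The other step, a number 10 percentage points lower from compound 2 to compound 3 (within the scatter), alters a group on an aromatic carbon and bears little on the present change. Compound 4 undoes the arrival of the 4-chlorophenyl group and carries instead a small carbonyl-bearing chain, as compound 1 does, so a large rise in this assay is expected, back toward the level of compound 1 at 86%. Carbamoyl is not ethoxycarbonyl, and compound 1 is the only anchor. The range is therefore kept wide.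

Compound 4 is estimated at 78% in this assay, between 50% and 100%. The expected step is a number 63 percentage points higher from compound 2 to compound 4 (beyond the scatter).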

Compound 4, largest response reached (reported as maximal response), in percent of the reference or control that the assay uses: 32%
The estimate for compound 4 lay 46 percentage points above the measured number, and the stated range ends above it.
By their numbers in this assay, from the lowest: compounds 3 and 2 (each within the scatter of the next); then compound 4; then compound 1.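

In this assay, the step of a number 17 percentage points higher from compound 2 to compound 4 (beyond the scatter) shows that a carbonyl-bearing chain on the saturated chain carbon bound to an aromatic nitrogen is not enough by itself to bring the response back to the level of compound 1. The step of a number 54 percentage points lower from compound 1 to compound 4 (beyond the scatter) shows that, with that chain otherwise unchanged, amino in place of ethoxy on a carbonyl carbon accounts for a large change, so the end group of the chain matters here and not only the loss of 4-chlorophenyl. No measured information on these compounds accounts for either step.

The compounds shown do not settle whether the high response of compound 1 is specific to ethoxycarbonyl or would be shared by a methyl ester, a carboxylic acid or an N-methyl amide. They also leave open how a longer chain between the aromatic nitrogen and the carbonyl would behave, or whether a small non-carbonyl group such as a simple amine on the chain could match either compound 1 or compound 4.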